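This account rests on a few compounds, and the source may have more. Where it says the series, first, only, none or still open, it means among the compounds named here.

In a functional assay on THP-1 cells (Homo sapiens), read by colorimetric assay, with stated times of 1 h and 1.5 h (on this read-out lower numbers stand for an effect already at smaller amounts and higher numbers for an effect only at larger amounts of compound), compound 1 `C=C(C(=O)OCC)C(O)c1ccccc1[N+](=O)[O-]` gives 200 nM. Compound 2 `C/C=C(/C(=O)OCC)C(O)c1ccccc1Cl` gives 158 nM, which lies within the scatter of the value for compound 1. Compound 3 `C/C=C(\C(=O)OCC)C(O)c1ccccc1Cl` gives 501 nM, a higher number than that of compound 1 and beyond the scatter. Compound 1 therefore stands level with compound 2 and clearly below compound 3.

Compound 4 `C=C(C(=O)OCC)C(O)c1ccccc1F` keeps the core of compound 1 but carries fluoro in place of nitro on an aromatic carbon. For the measured compounds named here, no measured step makes this exchange. Going by the values given here, the only measured step, a 3.2-fold higher number from compound 2 to compound 3 (0.50 log units; beyond the scatter), concerns the geometry of a double bond, so it says little about this change, although it shows that this assay can separate closely related structures. The nearest guide is compound 2 at 158 nM, which lacks the nitro group yet stays within the scatter of compound 1, although it also differs from compound 1 at the double bond. On that limited basis, no step beyond the scatter is expected. The expected change is a 1.4-fold higher number from compound 1 to compound 4 (0.15 log units; within the scatter), and its direction remains uncertain. For compound 4 the estimated value is 280 nM, with an expected range from 100 nM to 800 nM.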

Compound 4, half-maximal effective concentration: 251 nM
Compound 4: the middle estimate sits 1.1-fold (0.05 log units) above what was measured, within the range that was stated.
By their numbers in this assay, from the lowest: compounds 2, 1, 4 and 3 (each within the scatter of the next, the first and the last beyond it).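

In this assay, fluoro in place of nitro on an aromatic carbon, ortho to a group of 9 heavy atoms, gives a 1.3-fold higher number from compound 1 to compound 4 (0.10 log units; within the scatter). For the compounds shown here, no earlier pair of compounds differed at this group alone, so this is the first direct reading of the exchange, and it shows that nitro, with 3 heavy atoms and 2 hydrogen-bond acceptors, can give way to fluoro, with 1 heavy atom and 0 hydrogen-bond acceptors, without a step beyond the scatter in this pair. The evidence at hand concerns only how the double bond is drawn in another pair of compounds and gives no reason for this result.

The compounds shown leave open whether an amine, a carboxylic acid or a methoxy group at the same place would also stay within the scatter of compound 1. They also leave open whether the geometry of the double bond, which gave a 3.2-fold higher number from compound 2 to compound 3 (0.50 log units; beyond the scatter) with chloro on the aromatic ring, would matter to the same extent with fluoro or nitro there.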